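A few compounds are considered here, and "the series" means these few. Any claim that something is new, unique, unknown or untested is made for them only; others in the source may bear on it.

Working notes on the series.

Compound 2 (`COc1ccc(C(c2ccc(OCCO)cc2)c2cccc3ccccc23)c(OC)c1OC`) stands only at a limit in a functional assay on MDA-MB-231 cells (Homo sapiens) for inhibition, read by sulforhodamine B assay, with a stated time of 48 h; on this read-out higher numbers stand for weaker inhibition and lower numbers for stronger inhibition: in this assay compound 2 gives > 20000 nM, which is a limit of the assay and not a number. For the measured compounds named here, its single measured neighbour is compound 1 (`COc1ccc(C(OCc2ccccc2)c2cccc3ccccc23)c(OC)c1OC`); in this assay compound 1 gives > 20000 nM, again a limit. The step that the two limits leave unreadable from compound 1 to compound 2 therefore reads as 4-(2-hydroxyethoxy)phenyl in place of benzyloxy on a saturated chain carbon bound to two aromatic carbons, with no size attached. All that can be said is the limit of > 20000 nM in this assay, at which 2 of the 2 values shown sit.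

Compound 3 (`COc1ccc(C(c2ccccc2O)c2cccc3ccccc23)c(OC)c1OC`) is not yet measured. The change is 2-hydroxyphenyl in place of 4-(2-hydroxyethoxy)phenyl on a saturated chain carbon bound to two aromatic carbons, in words 2-hydroxyphenyl in place of 4-(2-hydroxyethoxy)phenyl on a saturated chain carbon bound to two aromatic carbons. Going by the values given here, no measured step in this assay bears on it with a readable size. Compound 3 is expected to sit at 20000 nM, within 8000 nM to 60000 nM, a step of a number no higher from compound 2 to compound 3 (the limit leaves the size open) expected to stay in the unreadable range.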

Compound 3, half-maximal inhibitory concentration: 17700 nM
Compound 3: middle estimate off by 1.1-fold (0.05 log units), on the high side; measured number inside the range.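

Compound 3 brings the first number rather than a limit in this assay, with 2-hydroxyphenyl on the saturated chain carbon bound to two aromatic carbons. The change reads as an at least 1.1-fold lower number from compound 2 to compound 3 (0.05 log units; that floor lies within the scatter), and with benzyloxy as the group replaced it reads as an at least 1.1-fold lower number from compound 1 to compound 3 (0.05 log units; that floor lies within the scatter); both are floors, so neither step is shown to exceed the scatter, and no gain can be claimed for 2-hydroxyphenyl over either group. The remaining step, between the two limits, cannot be read, and most of the series still sits at the limit: the limit of > 20000 nM in this assay, at which 2 of the 3 values shown sit.

From the compounds shown here alone, the true size of both steps stays open. Also open, going by these compounds, is whether a plain phenyl, or an amine or a carboxylic acid on that ring, would move the number beyond the scatter.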